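This account rests on a few compounds, and the source may have more. Where it says the series, first, only, none or still open, it means among the compounds named here.

Compound 1: `Nc1ccccc1NC(=O)c1ccc(CSC(=S)N2CCN(c3cccnc3)CC2)cc1`; in a functional assay on HeLa cells (Homo sapiens) for antiproliferative activity, read by CCK-8 assay, with a stated time of 72 h, tested at 2 uM (a lower number here means a weaker effect, a higher number a stronger effect of the compound at the concentration tested), compound 1 gives 66.2%.
Compound 2: `N#Cc1ccc(N2CCN(C(=S)SCc3ccc(C(=O)Nc4ccccc4N)cc3)CC2)cc1`; in this assay compound 2 gives 71.6%.
Compound 3: `Nc1ccccc1NC(=O)c1ccc(CSC(=S)N2CCN(c3ncccn3)CC2)cc1`; in this assay compound 3 gives 52.2%.

Compound 3 stands lowest of the three measured numbers. Its nearest neighbour is compound 1, and the step of a number 14 percentage points lower from compound 1 to compound 3 (beyond the scatter) lies beyond the scatter, as does the larger step of a number 19.4 percentage points lower from compound 2 to compound 3 (beyond the scatter). Between the other two, the step of a number 5.4 percentage points higher from compound 1 to compound 2 (within the scatter) stays within the scatter.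

Compound 4, `Nc1ccccc1NC(=O)c1ccc(CSC(=S)N2CCN(c3cnccn3)CC2)cc1`, is the next compound in this series. It differs from compound 3 by pyrazin-2-yl in place of pyrimidin-2-yl on an amine nitrogen in a ring. For the measured compounds named here, no measured step exchanges one six-membered aromatic ring with two hetero atoms for another; the steps that bear on it are the two swaps of the group on the amine nitrogen in a ring already described, which moved the read-out in this assay by modest amounts, and the pyridin-3-yl to 4-cyanophenyl swap, which stayed within the scatter. Since pyrazin-2-yl and pyrimidin-2-yl match in every count given, the expected step of a number 2.8 percentage points higher from compound 3 to compound 4 (within the scatter) is small and likely within the scatter. For compound 4 the estimate in this assay is 55%, with a range from 42% to 68%.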

Compound 4, a percentage reported as inhibition, at one concentration (the size of the read-out at that concentration, not a potency): 70.4%
Compound 4: middle estimate off by 15.4 percentage points, on the low side, outside the stated range (above it).
By their numbers in this assay, from the lowest: compound 3; then compounds 1, 4 and 2 (each within the scatter of the next).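

Pyrazin-2-yl and pyrimidin-2-yl match in every count and hold the same atoms joined differently, yet on the amine nitrogen in a ring this exchange alone gives, in this assay, a number 18.2 percentage points higher from compound 3 to compound 4 (beyond the scatter), so the read-out at this position depends on how the atoms of the aromatic ring are arranged and not only on what they are. Compound 4 also falls in with the other two, with a number 4.2 percentage points higher from compound 1 to compound 4 (within the scatter) and a number 1.2 percentage points lower from compound 2 to compound 4 (within the scatter), which leaves compound 3 as the only one of the four set apart by steps beyond the scatter, while pyridin-3-yl, 4-cyanophenyl and pyrazin-2-yl cannot be told apart. Nothing available accounts for the gap between the two arrangements.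

The compounds shown leave open whether pyridazin-3-yl or pyridin-2-yl on the same nitrogen would stand with compound 3 or with the other three. They also leave open what an amine or a carboxylic acid on the pyrazin-2-yl ring would do, and how the four compounds would rank by potency, since each number is a read-out at one concentration.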